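The source may hold more compounds than are shown below. What is called first, only, known or untested is meant among the compounds shown, and "the series" means these compounds.

Measured so far in an ADME assay on A549 cells (Homo sapiens) for cytotoxicity, with a stated time of 72 h; a higher number here means a weaker inhibitor, a lower number a stronger inhibitor:
compound 1 `COc1cc(NC(C)CCCN2C(=O)[C@@H](C)N(C(=O)CN)C2(C)C)c2ncccc2c1` gives > 100000 nM, a limit of the assay.
compound 2 `COc1cc(NC(C)CCCN2C(=O)CN(C(=O)CN)C2(C)C)c2ncccc2c1` gives > 100000 nM, also a limit.
compound 3 `COc1cc(NC(C)CCCN2C(=O)CN(C(=O)[C@@H](C)N)C2(C)C)c2ncccc2c1` gives 7800 nM.

Compound 2 stands at the limit of > 100000 nM in this assay, at which 2 of the 3 values shown sit, so its place in this assay is known only as a limit, and the step that the two limits leave unreadable from compound 1 to compound 2 is unreadable for the same reason. Compound 4 `COc1cc(NC(C)CCCN2C(=O)CN(C(=O)[C@H](N)CC(C)C)C2(C)C)c2ncccc2c1` differs from compound 2 in one place: isobutyl in place of hydrogen on a saturated chain carbon bound to an amine nitrogen and a carbonyl carbon. For the measured compounds named here, the one measured step at that carbon is an at least 12-fold lower number from compound 2 to compound 3 (1.10 log units; beyond the scatter), a methyl in place of hydrogen that brought the number down to a readable value. The isobutyl in compound 4 is a change at the same carbon, and a step in the same direction is expected. Compound 4 is accordingly estimated at 5000 nM, range 1500 nM to 30000 nM. That means an expected step of an at least 20-fold lower number from compound 2 to compound 4 (1.30 log units; beyond the scatter), with some chance that only a limit is again reported.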

Compound 4, half-maximal inhibitory concentration: 21200 nM
Estimate against measurement, compound 4: 4.2-fold (0.63 log units) below, within the range that was stated.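

Isobutyl at this carbon also gives a readable value, with an at least 4.7-fold lower number from compound 2 to compound 4 (0.67 log units; beyond the scatter) showing that compound 3 is not alone in lying clear of the limit. The longer group does not extend the drop seen with methyl, since a 2.7-fold higher number from compound 3 to compound 4 (0.43 log units; beyond the scatter) gives part of it back. The step from compound 2 stays a bound only, because compound 2 is known only as a limit: the limit of > 100000 nM in this assay, at which 2 of the 4 values shown sit.

On these data alone, whether a side chain ending in an amine or a carboxylic acid at this carbon would stay near compound 3 or return to the limit remains open.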